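Adding a Methyl Group on the Other Ring

The source may report more compounds than this note shows. Statements on the series, on what has been measured and on what is new or still open speak of the compounds shown alone.

Measured in a functional assay for activation of Alpha-1A adrenergic receptor (Homo sapiens), read by calcium flux; a higher number here means that more compound is needed for the effect, a lower number that less compound is needed:
compound 1 `c1csc(-c2ccccc2NCC2=NCCN2)c1` gives 2.24 nM
compound 2 `Cc1ccsc1-c1ccccc1NCC1=NCCN1` gives 0.851 nM
compound 3 `c1ccc(-c2ccccc2NCC2=NCCN2)nc1` gives 6.76 nM

Compound 2 differs from compound 1 by methyl in place of hydrogen on an aromatic carbon, and this step gave a 2.6-fold lower number from compound 1 to compound 2 (0.42 log units; beyond the scatter). Compound 3 differs from compound 1 by pyridin-2-yl in place of thiophen-2-yl on an aromatic carbon, which gave a 3.0-fold higher number from compound 1 to compound 3 (0.48 log units; beyond the scatter); against compound 2 the gap is a 7.9-fold higher number from compound 2 to compound 3 (0.90 log units; beyond the scatter), leaving compound 3 with the highest number of the three.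

Compound 4 `Cc1cccnc1-c1ccccc1NCC1=NCCN1` has not yet been measured. It differs from compound 3 by methyl in place of hydrogen on an aromatic carbon. Among the compounds with values here, this is the same kind of change as the one from compound 1 to compound 2, but not the same: in compound 2 the methyl sits on an aromatic carbon of a five-membered aromatic ring with 1 sulfur, next to the ring atom that bears a large group, two ring bonds from the ring sulfur, whereas in compound 4 it sits on an aromatic carbon of a six-membered aromatic ring with 1 nitrogen, ortho to a large group, two atoms from the ring nitrogen.

Within the data shown here, for compound 4 a step of about a 2.5-fold lower number from compound 3 to compound 4 (0.40 log units; beyond the scatter) in this assay is expected, resting on compound 1 and the single earlier step of a 2.6-fold lower number from compound 1 to compound 2 (0.42 log units; beyond the scatter), with added uncertainty because the ring that carries the methyl is different. The estimate for compound 4 is 2.7 nM, expected to fall between 1 nM and 7.5 nM.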

Compound 4, half-maximal effective concentration: 24.6 nM
Beside the measured number, compound 4's estimate is 9.1-fold (0.96 log units) below it, outside the stated range (above it).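

In this assay, putting the methyl on the core of compound 3 gave a 3.6-fold higher number from compound 3 to compound 4 (0.56 log units; beyond the scatter), so the same change pointed in opposite directions on the two cores: the same change on two cores in this assay, a 2.6-fold lower number (0.42 log units; beyond the scatter) from compound 1 to compound 2 and a 3.6-fold higher number (0.56 log units; beyond the scatter) from compound 3 to compound 4, 9.6-fold (0.98 log units) apart, beyond the scatter of two such steps In this small set, then, the effect of this methyl does not carry over from one core to the other, and a step measured on the core of compound 1 is a poor guide to the same step on the core of compound 3. Within the data shown here, with only one pair on each core, the data do not show why the two steps part ways, nor whether the identity of the ring carrying the methyl is what decides the direction.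

As far as these compounds go, it remains open whether the reversal is particular to methyl, or whether an ethyl group or a chlorine atom in the same place on both cores would also move the number in opposite directions. Also open, from the compounds shown here alone, is how a methyl on a different carbon of the ring with nitrogen would behave.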